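From butoxy to ethoxy on a shared core

The source may hold more compounds than are shown below. What is called first, only, known or untested is meant among the compounds shown, and "the series" means these compounds.

Compound 3 `CCCCOC1=C(CCC)C(=O)/C(=C(O)/C=C/c2ccccc2)C(=O)C1(CCC)CCC` gives 8.7 uM in a functional assay on HCT-8 cells (Homo sapiens) for antiproliferative activity, read by sulforhodamine B assay, with a stated time of 3 days; on this read-out higher numbers stand for an effect only at larger amounts of compound and lower numbers for an effect already at smaller amounts. Among the three measured compounds it holds the second highest number. Its nearest neighbour is compound 2 `CCCC1=C(OCC(C)C)C(CCC)(CCC)C(=O)/C(=C(O)\C=C\c2ccccc2)C1=O`, which gives 8 uM in this assay. The furthest is compound 1 `CCCC1=C(OCCC(C)C)C(CCC)(CCC)C(=O)/C(=C(O)\C=C\c2ccccc2)C1=O`, which gives 15.3 uM in this assay. The steps connecting them are all small: a 1.1-fold higher number from compound 2 to compound 3 (0.04 log units; within the scatter), a 1.8-fold lower number from compound 1 to compound 3 (0.25 log units; within the scatter) and a 1.9-fold lower number from compound 1 to compound 2 (0.28 log units; within the scatter).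

Compound 4 `CCCC1=C(OCC)C(CCC)(CCC)C(=O)/C(=C(O)\C=C\c2ccccc2)C1=O` differs from compound 3 by hydrogen in place of ethyl on a saturated chain carbon, two bonds along the chain from an oxygen on an unsaturated carbon, which, cut one bond further out, reads butoxy to ethoxy. For the measured compounds named here, two measured steps bear on this. The step from compound 1 to compound 2 likewise removes one carbon from the chain on the oxygen, and the step from compound 2 to compound 3 exchanges isopropyl for propyl at the same oxygen; both stayed within the scatter. Nothing in the three measured compounds points to a response of this chain beyond the scatter, so the expected step of a 1.2-fold lower number from compound 3 to compound 4 (0.06 log units; within the scatter) is one of no clear size in either direction. Compound 4 is therefore expected to give 7.5 uM in this assay, with a plausible range from 3.5 uM to 16 uM.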

Compound 4, concentration for half-maximal effect: 5.6 uM
Compound 4: middle estimate off by 1.3-fold (0.13 log units), on the high side, within the range that was stated.
By their numbers in this assay, from the lowest: compounds 4, 2, 3 and 1 (each within the scatter of the next, the first and the last beyond it).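

In this assay, ethoxy on the oxygen gives the first step among these chains to pass the usual scatter, a modest one (a 2.7-fold lower number from compound 1 to compound 4 (0.44 log units; beyond the scatter)), with hydrogen in place of isopropyl two bonds along the chain from an oxygen on an unsaturated carbon. The two other new comparisons stay inside the scatter (a 1.6-fold lower number from compound 3 to compound 4 (0.19 log units; within the scatter); a 1.4-fold lower number from compound 2 to compound 4 (0.15 log units; within the scatter)), so ethoxy cannot be told apart from the chains of compound 2 and compound 3, and only compound 1 and compound 4 are separated on this read-out. Since compound 2 and compound 3 are themselves within the scatter of compound 1, the separation rests on this single pair of compounds, and nothing shown gives a reason for it.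

The compounds shown leave open whether methoxy, or a longer chain such as hexyloxy, would extend this step or leave the number in this assay within the scatter. They also leave open how this position would respond to a chain ending in an amine or a carboxylic acid, since every group shown here on the oxygen is a plain saturated carbon chain.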